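This account rests on a few compounds, and the source may have more. Where it says the series, first, only, none or still open, it means among the compounds named here.

Measured in a physicochemical assay for lipophilicity, read by HPLC, at pH 7.5; a lower number here means a more polar compound, a higher number a more lipophilic compound:
- compound 1 `CC[C@@H](Nc1c(C#N)c(-c2ccc(-c3ccc(F)cc3)cc2)nc2cnccc12)C(N)=O` gives 2.7
- compound 2 `CC[C@@H](Nc1c(C#N)c(-c2ccc(-c3cnccc3C)cc2)nc2cnccc12)C(N)=O` gives 2
- compound 3 `CC(C)(CC(N)=O)c1c(C#N)c(-c2ccc(Br)cc2)nc2cnccc12` gives 2.1

In this assay compound 3 (2.1) stands within the scatter of compound 2 (2) and clearly under compound 1 (2.7).

Compound 4 `CC[C@@H](Nc1c(C#N)c(-c2ccc(Br)cc2)nc2cnccc12)C(N)=O` keeps the 4-bromophenyl group of compound 3 and changes one substituent on an aromatic carbon, ortho to a cyano group: a group of 7 heavy atoms (4 carbon, 2 nitrogen, 1 oxygen; no ring) in place of a group of 7 heavy atoms (5 carbon, 1 nitrogen, 1 oxygen; no ring), on an aromatic carbon. Within the data shown here, the entering (1-carbamoylpropyl)amino group is the one already carried by compound 1 and compound 2.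

Among the measured compounds shown here, the only measured step, a number 0.70 log units lower from compound 1 to compound 2 (beyond the scatter), is modest and lies beyond the scatter, but it concerns a different place on the molecule. For the measured compounds named here, it therefore bears on this change only indirectly, and no measured pair tests the exchange itself. Both groups also hold the same number of heavy atoms. On this basis, the expected change is small and in no firm direction, an estimated a number 0.10 log units higher from compound 3 to compound 4 (within the scatter) that would stay within the scatter. Compound 4 is therefore estimated at 2.2 with an expected range (1.8 to 2.6).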

Compound 4, distribution coefficient: 2.2
Beside the measured number, compound 4's estimate shows no gap at the digits printed; measured number inside the range.
By their numbers in this assay, from the lowest: compounds 2, 3 and 4 (each within the scatter of the next); then compound 1.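

Among these compounds, the pair of compound 3 and compound 4 is the first direct test of this position, on the aromatic carbon ortho to a cyano group, and in this assay it gives a number 0.10 log units higher from compound 3 to compound 4 (within the scatter). The entering (1-carbamoylpropyl)amino group has 2 hydrogen-bond donors and 2 hydrogen-bond acceptors against 1 of each in the leaving group, yet with equal heavy-atom counts this exchange leaves the two compounds level within the scatter in this one pair. Compound 4 also links the series at the other varied place, giving a number 0.20 log units higher from compound 2 to compound 4 (within the scatter) for the step from 4-methylpyridin-3-yl to bromo and a number 0.50 log units lower from compound 1 to compound 4 (beyond the scatter) for the step from 4-fluorophenyl to bromo, so that place separates these compounds only in the step from 4-fluorophenyl; no measurement available here accounts for either result.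

Going by these compounds, the exchange at this position has been read only with the 4-bromophenyl group, so whether it stays as small alongside the 4-fluorophenyl-bearing biaryl of compound 1 remains open. Also open, on these data alone, is how a simple primary amine, a carboxylic acid or a longer chain at this position would compare, as would the opposite stereocentre of the (1-carbamoylpropyl)amino group.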